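This account rests on a few compounds, and the source may have more. Where it says the series, first, only, none or still open, it means among the compounds named here.

Compound 1 `COc1cc(-c2nnc3n2NC(c2cccs2)C(C(=O)c2ccccc2)S3)cc(OC)c1OC` and compound 2 `COc1ccc(C(=O)C2Sc3nnc(-c4cc(OC)c(OC)c(OC)c4)n3NC2c2cccs2)cc1` share one core and differ only by a methoxy group placed on an aromatic carbon. In a functional assay on A549 cells (Homo sapiens) for cytotoxicity, read by MTT assay, with a stated time of 48 h (a higher number here means a weaker inhibitor, a lower number a stronger inhibitor), compound 1 gives 69400 nM. For compound 2 this assay reports only a limit, > 100000 nM. The step between them is therefore an at least 1.4-fold higher number from compound 1 to compound 2 (0.15 log units; that floor lies within the scatter), and it can be read only as a floor because of the limit of > 100000 nM in this assay, at which 1 of the 2 values shown sits. Compound 3 `COc1cc(-c2nnc3n2NC(c2cccs2)C(C(=O)c2ccc(Cl)cc2)S3)cc(OC)c1OC` is the next variation on compound 2: chloro in place of methoxy on an aromatic carbon. Among the measured compounds shown here, no measured step here involves a chloro group, so the only guide is the single methoxy step, which stayed within the scatter and gave no sign that this position moves the number much. The expectation for compound 3 is therefore an at least 1.1-fold lower number from compound 2 to compound 3 (0.07 log units; that floor lies within the scatter), no clear move beyond the scatter in either direction, with a fair chance that this assay again stops at its limit. Compound 3 is estimated at 85000 nM, with a range from 30000 nM to 250000 nM.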

Compound 3, half-maximal inhibitory concentration: 20100 nM
Beside the measured number, compound 3's estimate is 4.2-fold (0.63 log units) above it, and the stated range ends above it.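

Replacing the methoxy of the 4-methoxyphenyl group with the chloro of the 4-chlorophenyl group gives, in this assay, an at least 4.9-fold lower number from compound 2 to compound 3 (0.69 log units; beyond the scatter), so this position can move the number by more than the scatter, which the methoxy step alone never showed. From the compounds shown here alone, the true size of that step stays unknown, and it reads only as a floor because of a single value: the limit of > 100000 nM in this assay, at which 1 of the 3 values shown sits. Measured against hydrogen on the same aromatic carbon, where both values are actual numbers, chloro gives a 3.5-fold lower number from compound 1 to compound 3 (0.54 log units; beyond the scatter), a modest gain that is firmly established and shows that the substituent on this ring, para to a large group, matters for the cytotoxicity read-out.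

The compounds shown place only hydrogen, methoxy and chloro on this carbon, so three points cannot say whether a fluoro, a bromo, a methyl or an amine there would follow chloro or methoxy. Going by these compounds, they also give no reason for the drop, and since compound 3 still stands at 20100 nM, how far changes at this position can take the number remains open.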